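The source may report more compounds than this note shows. Statements on the series, on what has been measured and on what is new or still open speak of the compounds shown alone.

Measured in an in vitro ADME assay on microsomes from liver (Mus musculus) for pharmacokinetics, read by LC-MS, with a stated time of 10 min, tested at 1 uM; a higher number here means faster removal of the compound, a lower number slower removal:
- compound 1 `CN1C[C@H](C(=O)Nc2ccc(F)cc2)[C@@H](c2ccc(/C=C/C(=O)Nc3ccccc3N)cc2)C1`: 34 mL/min/kg
- compound 2 `Cc1ccc(NC(=O)[C@H]2CN(C)C[C@@H]2c2ccc(/C=C/C(=O)Nc3ccccc3N)cc2)cc1`: 62 mL/min/kg
- compound 3 `CN1C[C@H](C(=O)Nc2cccc(Cl)c2)[C@@H](c2ccc(/C=C/C(=O)Nc3ccccc3N)cc2)C1`: 58 mL/min/kg

Compound 3, at 58 mL/min/kg, stands among three values that all lie within the usual scatter of one another, so no order among them can be claimed. The next compound, compound 4 `CN1C[C@H](C(=O)Nc2ccc(F)c(Cl)c2)[C@@H](c2ccc(/C=C/C(=O)Nc3ccccc3N)cc2)C1`, differs from it in one place: fluoro in place of hydrogen on an aromatic carbon. Fluoro takes the place of hydrogen on an aromatic carbon, turning 3-chlorophenyl into 3-chloro-4-fluorophenyl.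

Among the compounds with values here, three measured steps bear on this: a 1.8-fold higher number from compound 1 to compound 2 (0.26 log units; within the scatter), a 1.1-fold lower number from compound 2 to compound 3 (0.03 log units; within the scatter) and a 1.7-fold higher number from compound 1 to compound 3 (0.23 log units; within the scatter). None leaves the scatter, although each alters the aromatic group on the amide-type nitrogen. Compound 4 unites the fluoro and chloro groups that differ across a 1.7-fold higher number from compound 1 to compound 3 (0.23 log units; within the scatter), so a value within the same span is expected. The expected change is a 1.2-fold lower number from compound 3 to compound 4 (0.08 log units; within the scatter), which would be no step beyond the scatter in either direction. For compound 4 the estimated clearance is 48 mL/min/kg, with an expected range from 26 mL/min/kg to 85 mL/min/kg.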

Compound 4, clearance: 34 mL/min/kg
For compound 4 the middle estimate is 1.4-fold (0.15 log units) above the measured one, within the range that was stated.
By their numbers in this assay, from the lowest: compounds 1, 4, 3 and 2 (each within the scatter of the next).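

In this assay, fluoro on the 3-chlorophenyl group, para to a large group and ortho to a chloro group, gives a 1.7-fold lower number from compound 3 to compound 4 (0.23 log units; within the scatter), so this new atom brings no change that can be told from the scatter. The earlier compounds shown here each carried one group on this aromatic ring, whereas compound 4 carries two, and the same holds for its other comparisons: a 1.8-fold lower number from compound 2 to compound 4 (0.26 log units; within the scatter) and, with chloro added to the 4-fluorophenyl group, no change at the digits printed from compound 1 to compound 4 (within the scatter). No measurement shown here offers an explanation for these numbers.

From the compounds shown here alone, whether an amine, a carboxylic acid or a methoxy group at this same place would also stay within the scatter remains open. So does whether any change to this aromatic group can move the number beyond the scatter.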